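A few compounds are considered here, and "the series" means these few. Any claim that something is new, unique, unknown or untested is made for them only; others in the source may bear on it.

Measured compounds in a functional assay on CHO cells with adenosine receptor A1 (Homo sapiens) as the target, read by cAMP accumulation and immunoassay, with a stated time of 6 min, tested at 10 uM; on this read-out lower numbers stand for a stronger effect and higher numbers for a weaker effect at the one concentration tested:
compound 1, `Nc1scc(CN2CCN(c3ccc(Cl)cc3F)CC2)c1C(=O)c1ccc(Cl)cc1`: -81%
compound 2, `Nc1scc(CN2CCN(c3ccc([N+](=O)[O-])cc3)CC2)c1C(=O)c1ccc(Cl)cc1`: -17%
compound 3, `Nc1scc(CN2CCN(c3cc(F)cc(F)c3)CC2)c1C(=O)c1ccc(Cl)cc1`: -79%

Compound 2 stands highest of the three numbers in this assay. Its nearest neighbour is compound 3, reached by the step of a number 62 percentage points lower from compound 2 to compound 3 (beyond the scatter); the step of a number 64 percentage points higher from compound 1 to compound 2 (beyond the scatter) is of the same size in the opposite direction. Compound 1 and compound 3 sit together, as the step of a number 2 percentage points higher from compound 1 to compound 3 (within the scatter) shows.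

Compound 4, `Nc1scc(CN2CCN(c3ccc(F)c(Cl)c3)CC2)c1C(=O)c1ccc(Cl)cc1`, is not yet measured. It differs from compound 2 in one place: 3-chloro-4-fluorophenyl in place of 4-nitrophenyl on an amine nitrogen in a ring. Going by the values given here, two measured steps bear on this change, since each of them replaces the 4-nitrophenyl with another substituted phenyl on the same ring nitrogen, or does the reverse: a number 62 percentage points lower from compound 2 to compound 3 (beyond the scatter) and a number 64 percentage points higher from compound 1 to compound 2 (beyond the scatter). Both are large and beyond the scatter, and the two substituted phenyls already measured give numbers within the scatter of each other. A large step downward is therefore expected, of about a number 59 percentage points lower from compound 2 to compound 4 (beyond the scatter). The estimate for compound 4 in this assay is -76%, with a range from -95% to -50%.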

Compound 4, a percentage reported as activity, at one concentration (the size of the read-out at that concentration, not a potency): -78%
Compound 4: middle estimate off by 2 percentage points, on the high side; the range from low to high includes it.
By their numbers in this assay, from the lowest: compounds 1, 3 and 4 (each within the scatter of the next); then compound 2.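

In this assay, 3-chloro-4-fluorophenyl on the ring nitrogen falls in with the two earlier phenyls bearing halogens, with a number 1 percentage points higher from compound 3 to compound 4 (within the scatter) and a number 3 percentage points higher from compound 1 to compound 4 (within the scatter) as the steps to it. Together with a number 61 percentage points lower from compound 2 to compound 4 (beyond the scatter) this leaves compound 2 as the only one of the four that stands apart, while three different arrangements of chlorine and fluorine on the phenyl cannot be told apart on this read-out. No measurement at hand explains why the 4-nitrophenyl differs from the other three groups.

Going by these compounds, whether a nitrile or a carboxylic acid on the phenyl would go with the 4-nitrophenyl or with the halogen-bearing phenyls stays open. So does the standing of the plain phenyl, which would show whether the halogens matter at all at this position on the shared core.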